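Propanoyl for cyclobutylcarbonyl on the tetrahydroquinoline amide

This account rests on a few compounds, and the source may have more. Where it says the series, first, only, none or still open, it means among the compounds named here.

Measured compounds:
- compound 1 `O=C(NCC1CCc2ccccc2N1Cc1ccccc1)C1CCC1`: "not determined" (no result reported)
- compound 2 `CCC(=O)NCc1ccc2c(OC)cccc2n1`: "not determined" (no result reported)
- compound 3 `CCNC(=O)NCC1CCc2ccccc2N1`: 2420 nM

Compound 1 stands on no number in a functional assay on CHO cells with melatonin receptor type 1A (Homo sapiens) as the target, read by GTPgammaS binding, with a stated time of 1 h; a lower number here means that less compound is needed, a higher number that more compound is needed for the effect; compound 2 likewise has no result there. Going by the values given here, the only measured value in this assay is that of compound 3, which gives 2420 nM.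

Compound 4 `CCC(=O)NCC1CCc2ccccc2N1Cc1ccccc1` is the next compound for this assay. It differs from compound 1 by ethyl in place of cyclobutyl on a carbonyl carbon. Among the compounds with values here, no step between measured compounds is available to anchor this change. With nothing measured for compound 1, the size of the step in this assay cannot be drawn from the data; the expectation is a step of no more than the usual scatter, in no firm direction.

For compound 4 the estimated value in this assay is 500 nM, expected to fall between 50 nM and 5000 nM.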

Compound 4, half-maximal effective concentration: 36 nM
For compound 4 the middle estimate is 14-fold (1.14 log units) above the measured one, outside the stated range (below it).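

No step can be read between compound 1 and compound 4: in this assay compound 1 has no single number. The compounds shown leave open whether propanoyl or cyclobutylcarbonyl gives the lower value. No evidence at hand bears on this result.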